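A Chlorine Added to the Phenyl Ring of Compound 1

The compounds below may be only part of what the source reports. "The series", "measured", "known", "first", "only" and "open" are said of these compounds alone.

Compound 1 `CN(C)CCn1cnnc1-c1cc(Oc2ccc(NC(=O)N/N=C/c3ccccc3)cc2F)ccn1` gives 1780 nM in a functional assay on NCI-H460 cells (Homo sapiens) for cytotoxicity, read by MTT assay, with a stated time of 72 h (on this read-out higher numbers stand for weaker inhibition and lower numbers for stronger inhibition), the lowest of the two numbers available. Compound 2 `Cn1ncnc1-c1cc(Oc2ccc(NC(=O)N/N=C/c3ccccc3)cc2F)ccn1` gives 52200 nM in this assay; the step of a 29-fold higher number from compound 1 to compound 2 (1.47 log units; beyond the scatter) concerns the group on the shared core and leaves the phenyl ring untouched. Compound 3 `CN(C)CCn1cnnc1-c1cc(Oc2ccc(NC(=O)N/N=C/c3ccc(Cl)cc3)cc2F)ccn1` differs from compound 1 by chloro in place of hydrogen on an aromatic carbon. Going by the values given here, no measured step bears on this change, so compound 3 is expected to stay within the scatter of compound 1, with a 1.2-fold lower number from compound 1 to compound 3 (0.07 log units; within the scatter) as the expected step. Compound 3 is therefore estimated at 1500 nM, between 500 nM and 4500 nM.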

Compound 3, half-maximal inhibitory concentration: 320 nM
For compound 3 the middle estimate is 4.7-fold (0.67 log units) above the measured one; the measured number lies below the stated range.
By their numbers in this assay, from the lowest: compound 3; then compound 1; then compound 2.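

The phenyl ring of compound 1 proves to be a position that responds: phenyl to 4-chlorophenyl, with the chloro para to a large group, gives a 5.6-fold lower number from compound 1 to compound 3 (0.75 log units; beyond the scatter) in this assay. Going by these compounds alone, the earlier step concerned only the group on the shared core, so this is the first change at the phenyl ring that moves the number beyond the scatter. Nothing given here bears on the reason for this step.

On these data alone, whether fluoro, methoxy or an amine at the same place would behave like chloro remains open. So does whether chloro would lower the number on compound 2 as well.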